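The source may report more compounds than this note shows. Statements on the series, on what has been measured and on what is new or still open speak of the compounds shown alone.

Three compounds built on one shared core were tested in a functional assay on A549 cells (Homo sapiens) for cytotoxicity, read by MTT assay, with a stated time of 24 h; a higher number here means a weaker inhibitor, a lower number a stronger inhibitor. Compound 1, `C=CC1=C(C(=O)NCc2ccccc2)C(c2ccc(OC)c(OC)c2)OC1`, reaches only a limit: in this assay compound 1 gives > 100000 nM, which is a limit and not a number. Compound 2, `C=CC1=C(C(=O)NCc2ccccc2)C(c2ccc(OC)cc2)OC1`, also stops at a limit, and in this assay compound 2 gives > 100000 nM. Compound 3, `C=CC1=C(C(=O)O)C(c2ccc(OC)cc2)OC1`, is no different in kind; in this assay compound 3 gives > 100000 nM, again a limit. Because every value sits at the limit of > 100000 nM in this assay, at which 3 of the 3 values shown sit, neither measured step can be read: the change from compound 1 to compound 2 is a step that the two limits leave unreadable from compound 1 to compound 2, and the change from compound 2 to compound 3 is a step that the two limits leave unreadable from compound 2 to compound 3. Among the measured compounds shown here, compound 2 thus stands at a limit, with no step of known size on either side of it.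

Compound 4, `C=CC1=C(C(=O)Nc2ccc(OCC)cc2)C(c2ccc(OC)cc2)OC1`, differs from compound 2 in one place: 4-ethoxyphenyl in place of benzyl on an amide-type nitrogen. The two measured steps bear on this change only in showing that exchanges at the amide group and at the aromatic ring left all three compounds at the limit. For the measured compounds named here, no step of readable size exists, so no direction beyond the scatter can be expected. Compound 4 is expected to remain at the limit, and the step this expectation means is a step that the limit leaves unreadable from compound 2 to compound 4. Compound 4 is estimated at 150000 nM, within a range from 50000 nM to 500000 nM.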

Compound 4, half-maximal inhibitory concentration: 17600 nM
Beside the measured number, compound 4's estimate is 8.5-fold (0.93 log units) above it; measured number outside the range, below it.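

In this assay, among the compounds shown here, the amide-type nitrogen is the first place where a change can be read: 4-ethoxyphenyl in place of benzyl gives an at least 5.6-fold lower number from compound 2 to compound 4 (0.75 log units; beyond the scatter). Compound 4 is thus the only compound shown with a measured number rather than a limit, so the group on this nitrogen can matter even though the earlier exchanges could not show it. The step is only a minimum because compound 2 sits at a limit, which is not a number: the limit of > 100000 nM in this assay, at which 3 of the 4 values shown sit.

The swap replaces the whole group at once, so the compounds shown cannot separate the contribution of the ethoxy group from that of the rest of the exchange; a plain phenyl, a 4-methoxyphenyl or a 4-butoxyphenyl on the same nitrogen would help to tell these apart. As far as these compounds go, it also stays open whether the 4-ethoxyphenyl amide would keep its effect with a second methoxy group on the other aromatic ring, as in compound 1, or whether an amine in place of the ethoxy group would do the same.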